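A Single Methyl Added to Compound 3

The source may report more compounds than this note shows. Statements on the series, on what has been measured and on what is new or still open speak of the compounds shown alone.

Three compounds that share the same amide-bearing side chain were tested in a functional assay on MCF7 cells (Homo sapiens) for cytotoxicity, read by CCK-8 assay, with a stated time of 24 h; on this read-out higher numbers stand for weaker inhibition and lower numbers for stronger inhibition. Compound 1 `C=C1CCC(c2csc(/C=C(\C)C(N)=O)c2)CC1` gives 8470 nM. Compound 2 `C/C(=C\c1cc(-c2ccccc2)co1)C(N)=O` gives 3340 nM. Compound 3 `C/C(=C\c1cc(-c2cccnc2)co1)C(N)=O` gives 13200 nM, the highest of the three numbers; its gap to compound 1 lies within the usual scatter, whereas compound 2 sits beyond the scatter with a clearly lower number.

Compound 4 `C/C(=C\c1cc(-c2ccc(C)nc2)co1)C(N)=O` has not yet been measured. It differs from compound 3 in one place only: methyl in place of hydrogen on an aromatic carbon. For the measured compounds named here, no pair of measured compounds here shows a change of this kind, so there is no direct precedent to lean on. Since the change adds just one heavy atom and nothing else, the step of a 1.2-fold lower number from compound 3 to compound 4 (0.08 log units; within the scatter) is expected to stay within the scatter, with no clear direction. Compound 4 is therefore estimated at 11000 nM, with a range from 4000 nM to 30000 nM.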

Compound 4, half-maximal inhibitory concentration: 10200 nM
Beside the measured number, compound 4's estimate is 1.1-fold (0.03 log units) above it; measured number inside the range.
By their numbers in this assay, from the lowest: compound 2; then compounds 1, 4 and 3 (each within the scatter of the next).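

In this assay, methyl in place of hydrogen on an aromatic carbon next to the ring nitrogen and para to a large group gives a 1.3-fold lower number from compound 3 to compound 4 (0.11 log units; within the scatter) in this series. For the compounds shown here, this is the only pair here that differs in one place, so it gives the first direct reading of this change: at this position of the six-membered aromatic ring with 1 nitrogen, one added carbon leaves no change that can be told from the scatter. No measurement at hand bears on this result.

As far as these compounds go, a single methyl says little about larger or different groups, so whether an ethyl, a methoxy or an amine on the same carbon would also leave the number unchanged remains open. From the compounds shown here alone, whether a methyl on the other carbons of this ring would behave in the same way also remains open.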